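Methyl on the triazole phenyl of a sulfonamide

The compounds below may be only part of what the source reports. "The series", "measured", "known", "first", "only" and "open" are said of these compounds alone.

Compound 1 `O=c1[nH]cc(S(=O)(=O)Nc2ccccc2-c2cn(-c3ccccc3)nn2)c(=O)[nH]1` gives 6650 nM in a functional assay on OVCAR-3 cells (Homo sapiens) for antiproliferative activity, read by MTT assay, with a stated time of 24 h (a lower number here means a stronger inhibitor, a higher number a weaker inhibitor), and compound 2 `O=c1[nH]cc(S(=O)(=O)Nc2ccccc2-c2cn(-c3ccccc3Cl)nn2)c(=O)[nH]1` gives 3170 nM. The change a 2.1-fold lower number from compound 1 to compound 2 (0.32 log units; beyond the scatter) was a modest gain. Compound 3 `O=c1[nH]cc(S(=O)(=O)Nc2cccc(-c3cn(-c4ccccc4)nn3)c2)c(=O)[nH]1` reached only the limit of this assay, at > 20000 nM; one of the three values shown rests at this point, (the limit of > 20000 nM in this assay, at which 1 of the 3 values shown sits). Compound 4 `Cc1cccc(-n2cc(-c3cccc(NS(=O)(=O)c4c[nH]c(=O)[nH]c4=O)c3)nn2)c1` differs from compound 3 by methyl in place of hydrogen on an aromatic carbon. Going by the values given here, the only measured step on this phenyl ring, from compound 1 to compound 2, was a modest gain, so for compound 4 a small step in the stronger direction, or none beyond the scatter, is expected, estimated as a number no higher from compound 3 to compound 4 (the limit leaves the size open). Compound 4 is therefore estimated at 20000 nM, between 8000 nM and 60000 nM, with a fair chance that only a limit is again reported.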

Compound 4, half-maximal inhibitory concentration: 4080 nM
Beside the measured number, compound 4's estimate is 4.9-fold (0.69 log units) above it; measured number below the stated range.
By their numbers in this assay, from the lowest: compounds 2, 4 and 1 (each within the scatter of the next, the first and the last beyond it). At a limit, above all of these: compound 3.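

The methyl group, on an aromatic carbon meta to a large group, gives an at least 4.9-fold lower number from compound 3 to compound 4 (0.69 log units; beyond the scatter) in this assay, the only step shown on the core of compound 3. One added carbon on this phenyl ring is thus enough to bring that core to a measured number. The size of the step stays open at one end, because compound 3 rests at a limit: the limit of > 20000 nM in this assay, at which 1 of the 4 values shown sits.

Open remains whether this gain belongs to methyl itself or would also follow from an amine, a methoxy group or a longer chain such as ethyl on the same carbon.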